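The source may report more compounds than this note shows. Statements on the series, on what has been measured and on what is new or still open speak of the compounds shown alone.

Of the compounds shown here, two have been measured here, and both share the same core. Compound 1 `CC(C)Oc1cccc2ccc(N)nc12` carries an isopropyl group on the aromatic oxygen; in an assay on cells with melanin-concentrating hormone receptor 1 (Homo sapiens) as the target, read by radioligand binding (on this read-out lower numbers stand for stronger inhibition and higher numbers for weaker inhibition), compound 1 gives 437 nM. Compound 2 `Nc1ccc2cccc(OCC3CC4CCC3C4)c2n1` carries a bulkier bicyclic group on that oxygen, and in this assay compound 2 gives 137 nM. Among these two numbers compound 1 stands highest, so it is the weaker inhibitor of the pair, and the gap to compound 2 is beyond the usual scatter.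

The step followed here leads from compound 1 to compound 3 `CC(C)=CCOc1cccc2ccc(N)nc12`, which has not been measured. The change is 3-methylbut-2-en-1-yl in place of isopropyl on an oxygen on an aromatic ring, so the small branched group on the oxygen is exchanged for a longer unsaturated chain.

For the measured compounds named here, no directly comparable step between measured compounds exists, so the expectation rests on compound 2, which gives 137 nM with a different group at the same oxygen. The expected step of a 1.7-fold lower number from compound 1 to compound 3 (0.24 log units; within the scatter) is toward a lower number, of modest size, but it may still fall within the scatter. Compound 3 is therefore expected to give about 250 nM, with a likely range from 100 nM to 650 nM.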

Compound 3, half-maximal inhibitory concentration: > 2000 nM
Compound 3 ended at the assay's limit; the forecaster's own chance of this, stated with the estimate: 0%; middle value at least 8.0-fold (0.90 log units) away from the limit.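

Compound 3 reads > 2000 nM in this assay, which is a limit of the assay and not a number. Putting 3-methylbut-2-en-1-yl in place of isopropyl on this oxygen gives an at least 4.5-fold higher number from compound 1 to compound 3 (0.66 log units; beyond the scatter), so a change at this position can push the value up as well as down, a direction the two earlier compounds could not reveal. Compound 2, whose bicyclic group is also bulkier than isopropyl, gives 137 nM, so among these three compounds a larger group on the oxygen does not by itself bring a lower number.

From the compounds shown here alone, what remains open is whether the double bond or the longer chain accounts for the step, and a saturated 3-methylbutyl group or a cyclopentyl ring on the same oxygen is the kind of group that could help to tell these apart. The full size of the step also stays unknown, because the reading for compound 3 ends at the limit: the limit of > 2000 nM in this assay, at which 1 of the 3 values shown sits.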